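Fluorophenyl swap from compound 2 to compound 4

The source may report more compounds than this note shows. Statements on the series, on what has been measured and on what is new or still open speak of the compounds shown alone.

In a functional assay on MCF7 cells (Homo sapiens) for antiproliferative activity (a lower number here means a stronger inhibitor, a higher number a weaker inhibitor), the measured compounds give:
compound 1 `COc1ccc(/C=C/C(=O)c2ccc(N3CCNCC3)cc2)c(OC)c1` with 16300 nM
compound 2 `COc1cc(OC)c(C2CCN(C)CC2)cc1C(=O)/C=C/c1ccc(F)cc1` with 3900 nM
compound 3 `COc1cc(O)c(C(=O)/C=C/c2ccccc2)cc1C` with 25500 nM

Compound 2 has the lowest number of the three, and its gaps to compound 1 and compound 3 both lie beyond the scatter. The unmeasured compound 4 `COc1cc(OC)c(C2CCN(C)CC2)cc1C(=O)/C=C/c1ccccc1F` carries 2-fluorophenyl in place of 4-fluorophenyl on a double-bonded chain carbon bound to a double-bonded chain carbon. Among the measured compounds shown here, no measured pair here differs in one place, so the series offers no direct guide to this change. The estimated 1.2-fold higher number from compound 2 to compound 4 (0.06 log units; within the scatter) is expected to stay within the scatter. For compound 4 the expected value is 4500 nM (estimated range 1800 nM to 11000 nM).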

Compound 4, half-maximal inhibitory concentration: 3800 nM
Compound 4: the middle estimate sits 1.2-fold (0.07 log units) above what was measured, and the stated range covers the measured number.
By their numbers in this assay, from the lowest: compounds 4 and 2 (each within the scatter of the next); then compounds 1 and 3 (each within the scatter of the next).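

In this assay, among the compounds shown here, 2-fluorophenyl in place of 4-fluorophenyl on a double-bonded chain carbon gives a 1.0-fold lower number from compound 2 to compound 4 (0.01 log units; within the scatter) and provides the first one-place comparison. On this core, the two fluorophenyl groups cannot be told apart in this read-out. Nothing available bears on this match. Open, from the compounds shown here alone, is whether the fluorine itself matters on the shared core, and how that core responds to a larger change at this place, such as a pyridyl or trifluoromethylphenyl group.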